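Piperidinyl amides on a shared quinazoline-type core: one further variant

The compounds below may be only part of what the source reports. "The series", "measured", "known", "first", "only" and "open" are said of these compounds alone.

Measured compounds:
Compound 1 `COCCNC(=O)C1CCN(c2nc(N)c3cc(OC)c(OC)cc3n2)CC1`: 1.13 nM
Compound 2 `COc1cc2nc(N3CCC(C(=O)NCCOc4ccccc4)CC3)nc(N)c2cc1OC`: 0.42 nM

In an assay on isolated protein for displacement of a labelled ligand from Adrenergic receptor alpha-1 (Rattus norvegicus) (on this read-out higher numbers stand for weaker inhibition and lower numbers for stronger inhibition), compound 1 gives 1.13 nM, the highest of the two numbers; compound 2 sits a 2.7-fold lower number from compound 1 to compound 2 (0.43 log units; beyond the scatter) away. Compound 3 `COc1cc2nc(N3CCC(CC(=O)NCC4CC4)CC3)nc(N)c2cc1OC` carries ((cyclopropylmethyl)carbamoyl)methyl in place of (2-methoxyethyl)carbamoyl on a saturated ring carbon. Within the data shown here, no measured step touches this kind of change: the one step, a 2.7-fold lower number from compound 1 to compound 2 (0.43 log units; beyond the scatter), alters the far end of the amide chain and is modest. Compound 3 is therefore expected near compound 1, with a 1.1-fold lower number from compound 1 to compound 3 (0.05 log units; within the scatter), inside the scatter. For compound 3 the estimate is 1 nM, expected between 0.3 nM and 4 nM.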

Compound 3, inhibition constant: 1.08 nM
For compound 3 the middle estimate is 1.1-fold (0.03 log units) below the measured one; low and high end bracket the measured number.
By their numbers in this assay, from the lowest: compound 2; then compounds 3 and 1 (each within the scatter of the next).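

In this assay, the swap of (2-methoxyethyl)carbamoyl for ((cyclopropylmethyl)carbamoyl)methyl on the saturated ring carbon gives a 1.0-fold lower number from compound 1 to compound 3 (0.02 log units; within the scatter). This shows that a change reaching the attachment to the ring, and not only the far end of the chain, can leave the number unchanged, even though the entering group carries a three-membered ring and one hydrogen-bond acceptor instead of two. No available evidence bears on this result.

The compounds shown do not separate the effect of the altered link to the carbonyl from that of the new chain end. On these data alone, how a carboxylic acid or an amine on this ring carbon would read also remains open.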